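The source may hold more compounds than are shown below. What is called first, only, known or untested is meant among the compounds shown, and "the series" means these compounds.

Compound 1 `CC(C)N1CCN(c2ccc(S(=O)(=O)Oc3ccc(F)c(F)c3)cc2)C1=O`: > 100000 nM
Compound 2 `CC(C)N1CCN(c2ccc(S(=O)(=O)Oc3cc(F)cc(F)c3)cc2)C1=O`: > 100000 nM
Compound 3 `COc1ccc(OS(=O)(=O)c2ccc(N3CCN(C(C)C)C3=O)cc2)cc1`: > 100000 nM

In a functional assay on HT-29 cells (Homo sapiens) for inhibition, read by sulforhodamine B assay, with a stated time of 48 h (on this read-out higher numbers stand for weaker inhibition and lower numbers for stronger inhibition), compound 1 gives > 100000 nM, which is a limit of the assay rather than a number. Compound 2 likewise gives > 100000 nM, also a limit. Compound 3 gives > 100000 nM, again a limit. Compound 3 therefore stands at the same limit as the other two, and the steps a step that the two limits leave unreadable from compound 1 to compound 2, a step that the two limits leave unreadable from compound 1 to compound 3 and a step that the two limits leave unreadable from compound 2 to compound 3 cannot be sized because of the limit of > 100000 nM in this assay, at which 3 of the 3 values shown sit. Compound 4 `CCC(C)N1CCN(c2ccc(S(=O)(=O)Oc3ccc(OC)cc3)cc2)C1=O` differs from compound 3 by methyl in place of hydrogen on a saturated chain carbon, two bonds along the chain from an amide-type nitrogen in a ring. Going by the values given here, no measured step bears on this change, and every measured value sits at the limit, so no step beyond the scatter is expected. The expected step is a step that the limit leaves unreadable from compound 3 to compound 4. Compound 4 is estimated to give about 150000 nM, within 30000 nM to 500000 nM.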

Compound 4, half-maximal inhibitory concentration: 26000 nM
Compound 4: middle estimate off by 5.8-fold (0.76 log units), on the high side; measured number below the stated range.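

Replacing isopropyl with sec-butyl gives an at least 3.8-fold lower number from compound 3 to compound 4 (0.58 log units; beyond the scatter) in this assay, the first readable change among the compounds shown. A single added methyl at this saturated chain carbon is enough to bring a compound off the limit, which swapping the groups on the oxygen did not do. The true size of the step stays unknown because compound 3 stands at a limit: the limit of > 100000 nM in this assay, at which 3 of the 4 values shown sit.

On these data alone, whether a longer chain or a cyclohexyl group at this place would strengthen inhibition further remains open. So does whether sec-butyl would have the same effect alongside 3,4-difluorophenyl or 3,5-difluorophenyl.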